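Terminal alkyne analogue of the dihydroxy long-chain triol series

The source may report more compounds than this note shows. Statements on the series, on what has been measured and on what is new or still open speak of the compounds shown alone.

Measured so far:
compound 1 `CCCCCCCCCCCCCCCC(O)CC(O)CO`, 2.7 ug/mL
compound 2 `C=CCCCCCCCCCCCC(O)CC(O)CO`, 3.6 ug/mL

Compound 1 `CCCCCCCCCCCCCCCC(O)CC(O)CO` gives 2.7 ug/mL in a functional assay on A498 cells (Homo sapiens) for cytotoxicity, read by MTT assay; on this read-out higher numbers stand for weaker inhibition and lower numbers for stronger inhibition. Compound 2 `C=CCCCCCCCCCCCC(O)CC(O)CO` gives 3.6 ug/mL in this assay. The two numbers lie within the scatter of each other, as the step of a 1.3-fold higher number from compound 1 to compound 2 (0.12 log units; within the scatter) shows; on the numbers shown, compound 2 stands alongside compound 1 with nothing separating them.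

Compound 3 `C#CCCCCCCCCCCCC(O)CC(O)CO` is not yet measured in this assay. It differs from compound 2 in one place: ethynyl in place of vinyl on a saturated chain carbon, ten or more bonds along the chain from an oxygen on a saturated carbon. Among the compounds with values here, the only measured step that bears on the chain end is a 1.3-fold higher number from compound 1 to compound 2 (0.12 log units; within the scatter), which was within the scatter. Changing that end from butyl to vinyl did nothing beyond the scatter, and the further change from vinyl to ethynyl is of the same kind and at the same place, so no step beyond the scatter is expected from compound 2 to compound 3.

For compound 3 the expected step is no change at the digits printed from compound 2 to compound 3 (within the scatter). Compound 3 is thus estimated at 3.6 ug/mL in this assay, with a range from 1.8 ug/mL to 7.2 ug/mL.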

Compound 3, half-maximal inhibitory concentration: 4.1 ug/mL
Compound 3: middle estimate off by 1.1-fold (0.06 log units), on the low side; low and high end bracket the measured number.
By their numbers in this assay, from the lowest: compounds 1, 2 and 3 (each within the scatter of the next).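

Working notes: in this assay the chain end has now been read with three groups, and ethynyl in place of vinyl gives a 1.1-fold higher number from compound 2 to compound 3 (0.06 log units; within the scatter), while ethynyl in place of butyl gives a 1.5-fold higher number from compound 1 to compound 3 (0.18 log units; within the scatter). The earlier step covered only butyl and vinyl; these two steps add a triple bond at the same place and show that the pair furthest apart in this set also stays within the scatter. At that place, this read-out therefore does not separate butyl, vinyl and ethynyl, and no accompanying measurement speaks to why these three ends read alike.

On these data alone, all three ends contain carbon only, so it remains open whether an amine or a carboxylic acid at this place would give a step beyond the scatter. Also open, as far as these compounds go, is how a longer chain, or a shorter one, would read with any of these end groups in this assay.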